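Working notes: from thiophen-2-yl to 5-bromofuran-2-yl

This account rests on a few compounds, and the source may have more. Where it says the series, first, only, none or still open, it means among the compounds named here.

Measured so far in a functional assay on PC-3 cells (Homo sapiens) for inhibition, read by MTT assay (a higher number here means a weaker inhibitor, a lower number a stronger inhibitor), as half-maximal inhibitory concentration
- compound 1 `O=C(CCCCCCC(=O)Nc1nnc(-c2ccco2)s1)NO` gives 880 nM
- compound 2 `O=C(CCCCCCC(=O)Nc1nnc(-c2cccs2)s1)NO` gives 880 nM

Compound 2 stands level with compound 1 at the digits shown, with nothing else measured to place it against. The next structure is compound 3 `O=C(CCCCCCC(=O)Nc1nnc(-c2ccc(Br)o2)s1)NO`, which carries 5-bromofuran-2-yl in place of thiophen-2-yl on an aromatic carbon of the shared core, as counted here: 5-bromofuran-2-yl in place of thiophen-2-yl on an aromatic carbon. Among the measured compounds shown here, only one measured step bears on this change, no change at the digits printed from compound 1 to compound 2 (within the scatter), an exchange of the same two ring types. For the measured compounds named here, no measured compound carries bromine, so that part of the change is untested. In this assay the expected result is a 1.3-fold lower number from compound 2 to compound 3 (0.10 log units; within the scatter), with no step beyond the scatter and no firm direction. For compound 3 the estimated value is 700 nM, with an expected range from 300 nM to 1700 nM as the likely span.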

Compound 3, half-maximal inhibitory concentration: 880 nM
Compound 3: the middle estimate sits 1.3-fold (0.10 log units) below what was measured; low and high end bracket the measured number.
By their numbers in this assay, from the lowest: compounds 1, 2 and 3 (each within the scatter of the next).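

In this assay, bromo in place of hydrogen on an aromatic carbon gives no change at the digits printed from compound 1 to compound 3 (within the scatter), and 5-bromofuran-2-yl in place of thiophen-2-yl gives no change at the digits printed from compound 2 to compound 3 (within the scatter). Unlike the earlier exchange of one unsubstituted ring for another, these steps put a substituent on the ring, and the read-out stays level. Among these three compounds, the position on the shared core therefore accepts 5-bromofuran-2-yl as well as furan-2-yl and thiophen-2-yl, and nothing available accounts for this flat result.

As far as these compounds go, it remains open whether a different substituent on this ring, such as an amine or a carboxylic acid, would stay level with these compounds. Also open, from the compounds shown here alone, is whether a longer chain in the shared core would move the number in this assay beyond the scatter.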